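Methylsulfonyl replaced on an amine nitrogen in compound 3

The source may report more compounds than this note shows. Statements on the series, on what has been measured and on what is new or still open speak of the compounds shown alone.

Compound 1 `O=C(CCl)N[C@H]1[C@H]([C@@H](O)[C@H](O)CNC(=O)c2ccc(Cl)cc2)O[C@@](OCc2cccc(F)c2F)(C(=O)O)C[C@@H]1O`: 0.35
Compound 2 `CS(=O)(=O)N[C@H]1[C@H]([C@@H](O)[C@H](O)CNC(=O)c2ccc(Cl)cc2)O[C@@](OCc2cccc(F)c2F)(C(=O)O)C[C@@H]1O`: -0.17

Among the measured compounds shown here, in a physicochemical assay for lipophilicity, using the shake flask method, measured as octanol-water partition, at pH 7.4 (on this read-out higher numbers stand for higher lipophilicity and lower numbers for lower lipophilicity), compound 2 holds the lower of the two numbers so far, at -0.17, while compound 1 stands higher at 0.35. Compound 3 `O=C(CC1CCC1)N[C@H]1[C@H]([C@@H](O)[C@H](O)CNC(=O)c2ccc(Cl)cc2)O[C@@](OCc2cccc(F)c2F)(C(=O)O)C[C@@H]1O` has not yet been measured. Its structure departs from that of compound 2 as follows: (cyclobutylmethyl)carbonyl in place of methylsulfonyl on an amine nitrogen. In words, (cyclobutylmethyl)carbonyl stands in place of methylsulfonyl on an amine nitrogen.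

For the measured compounds named here, one measured step bears on this change: a number 0.52 log units lower from compound 1 to compound 2 (beyond the scatter). That step was modest but beyond the scatter, and it involved methylsulfonyl in place of (chloromethyl)carbonyl on an amine nitrogen. The new change runs the other way, from methylsulfonyl to a carbonyl-linked group, so a rise is expected. Going by the values given here, the entering group also has more carbon than (chloromethyl)carbonyl, so a rise larger than that one step is expected, although no measured compound yet carries it. The expected change is a number 1.32 log units higher from compound 2 to compound 3 (beyond the scatter), which would lie beyond the scatter. In this assay, compound 3 is estimated at 1.15, with an expected range of 0.6 to 1.7.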

Compound 3, distribution coefficient: 0.75
The estimate for compound 3 lay 0.40 log units above the measured number; low and high end bracket the measured number.
By their numbers in this assay, from the lowest: compound 2; then compound 1; then compound 3.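

In this assay, the swap from methylsulfonyl to (cyclobutylmethyl)carbonyl on the amine nitrogen gives a number 0.92 log units higher from compound 2 to compound 3 (beyond the scatter), so a second carbonyl-linked group now stands above the methylsulfonyl compound, and neither of the two carbonyl compounds goes against that order. The earlier pair could only set one carbonyl-linked group against methylsulfonyl, whereas compound 1 and compound 3 keep the carbonyl and differ only on the saturated chain carbon bound to it: cyclobutyl in place of chloro gives a number 0.40 log units higher from compound 1 to compound 3 (beyond the scatter), showing that the read-out at this position also responds to what the carbonyl carries. No measurement shown here accounts for either step.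

As far as these compounds go, it remains open whether an acetyl group, a longer straight alkyl chain, or a carbonyl-linked group carrying an amine or a carboxylic acid would fit the same order on this nitrogen. Also unresolved is how much of the rise belongs to the link and how much to the carbon group, which a cyclobutylmethylsulfonyl group on the same nitrogen would help to separate.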